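The source may hold more compounds than are shown below. What is called first, only, known or untested is meant among the compounds shown, and "the series" means these compounds.

Compound 1 `Cn1ncc2cc(-c3ccc4oc(NC5CCCCC5)nc4c3)ccc21` is the reference point here. Among the compounds with values here, in an assay on HEK293 cells for inhibition of Fatty-acid amide hydrolase 1 (Homo sapiens), read by fluorescence (a higher number here means a weaker inhibitor, a lower number a stronger inhibitor), compound 1 gives 61 nM, the lowest of the three numbers measured so far. Compound 2 `Cn1ccc2cc(-c3ccc4oc(Nc5cccnc5)nc4c3)ccc21` gives 226 nM in this assay, and compound 3 `Cn1ccc2cc(-c3ccc4oc(N5Cc6cccnc6C5)nc4c3)ccc21` gives 211 nM; both carry a different core from compound 1, so their gap to compound 1 cannot be pinned on one change.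

The unmeasured compound 4 `Cn1ncc2cc(-c3ccc4oc(N5Cc6ccccc6C5)nc4c3)ccc21` keeps the core of compound 1 and changes only the group on the oxazole ring: a group of 9 heavy atoms (8 carbon, 1 nitrogen; one five-membered non-aromatic ring with 1 hetero atom, one six-membered aromatic ring of carbon only) in place of a group of 7 heavy atoms (6 carbon, 1 nitrogen; one six-membered non-aromatic ring of carbon only), on an aromatic carbon. Within the data shown here, the single measured step that resembles this is the move from an aromatic amine to a fused bicyclic amine, which gave a 1.1-fold lower number from compound 2 to compound 3 (0.03 log units; within the scatter). That step is only a loose guide. The group that leaves there is not the cyclohexylamino of compound 1, and the core differs. Still, it shows that closing the amine into a ring can leave this assay essentially unchanged.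

On that basis compound 4 is expected to stay close to compound 1, with a step of a 1.6-fold higher number from compound 1 to compound 4 (0.21 log units; within the scatter) that is not expected to exceed the scatter. The estimate for compound 4 is 100 nM, within a range from 30 nM to 330 nM.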

Compound 4, half-maximal inhibitory concentration: 1.2 nM
The estimate for compound 4 lay 83-fold (1.92 log units) above the measured number; measured number below the stated range.
By their numbers in this assay, from the lowest: compound 4; then compound 1; then compounds 3 and 2 (each within the scatter of the next).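

At this position, on an aromatic carbon next to the ring nitrogen and next to the ring oxygen, this assay can respond strongly to the group: putting the fused bicyclic amine in place of cyclohexylamino gives a 51-fold lower number from compound 1 to compound 4 (1.71 log units; beyond the scatter) on the core of compound 1. Within the data shown here, the only earlier step here, a 1.1-fold lower number from compound 2 to compound 3 (0.03 log units; within the scatter), stayed within the scatter, but it involved different groups on a different core, so it gave no sign of such sensitivity. This change removes a hydrogen-bond donor and adds a six-membered aromatic ring of carbon only at the same time, and no measurement here bears on why the number falls.

Which of these differences carries the step stays open. A plain pyrrolidine on the core of compound 1, attached through its nitrogen, would help separate them.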